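The source may report more compounds than this note shows. Statements on the series, on what has been measured and on what is new or still open speak of the compounds shown alone.

In an ADME assay on BJ cells (Homo sapiens) for cytotoxicity, with a stated time of 72 h (on this read-out lower numbers stand for an effect already at smaller amounts and higher numbers for an effect only at larger amounts of compound), the evidence is thin. Compound 1 `COc1cc2ncnc(-n3nc(-c4ccccn4)nc3N)c2cc1[N+](=O)[O-]` gives > 13000 nM, which is a limit of the assay and not a number. Among the compounds with values here, that is the only reading available to work from: the limit of > 13000 nM in this assay, at which 1 of the 2 values shown sits. For compound 2 `Nc1nc(-c2ccccn2)nn1-c1ncnc2cc(N3CCNCC3)c([N+](=O)[O-])cc12` the record reads "not determined" (no result reported), so it adds nothing to the comparison.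

Compound 3 `COc1cc2ncnc(-n3nc(-c4ccccn4)nc3N)c2cc1OCc1ccccc1` keeps the core of compound 1 and differs from it in one place: benzyloxy in place of nitro on an aromatic carbon, ortho to a methoxy group. The count of that exchange is benzyloxy in place of nitro on an aromatic carbon. Within the data shown here, no measured pair shows what such an exchange does here, so the expectation rests on compound 1 alone, with its limit of > 13000 nM. On that basis no step beyond the scatter is expected in this assay, in either direction, and the assay may well report only a limit again. The expected step that the limit leaves unreadable from compound 1 to compound 3 is therefore an estimate with little behind it. Compound 3 is expected at 14000 nM, with an estimated range of 5000 nM to 30000 nM.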

Compound 3, half-maximal effective concentration: > 27000 nM
Compound 3: only a limit was reported; the forecaster's own chance of this, stated with the estimate: 60%; at least 1.9-fold (0.28 log units) between middle value and limit.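

In this assay compound 3 gives > 27000 nM, which is a limit of the assay and not a number. Compound 1 also stands at a limit, so no step can be read between compound 1 and compound 3. From the compounds shown here alone, what benzyloxy in place of nitro does to this read-out remains open, as does the actual value of either compound.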